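The compounds below may be only part of what the source reports. "The series", "measured", "known", "first", "only" and "open" are said of these compounds alone.

Compound 3 `C#CC(C)OC(=O)c1ccc(C(CC)(CC)c2ccc(OCC(O)C(C)(C)C)c(C)c2)n1CC` is an ester in which a (1-methylprop-2-yn-1-yl)oxy group sits on the carbonyl carbon attached to the shared core. In an assay on HL-60 cells for agonist activity at vitamin D3 receptor (Homo sapiens), read by microscopy, with a stated time of 96 h (a lower number here means that less compound is needed, a higher number that more compound is needed for the effect), compound 3 gives 200 nM, which places it second highest of the three numbers measured: compound 1 `CCN(CC)CCCNC(=O)c1ccc(C(CC)(CC)c2ccc(OCC(O)C(C)(C)C)c(C)c2)n1CC` gives 66 nM, and compound 2 `CCn1c(C(=O)N(C)c2ccccc2)ccc1C(CC)(CC)c1ccc(OCC(O)C(C)(C)C)c(C)c1` gives 6400 nM. The two measured steps that change the same position are a 3.0-fold higher number from compound 1 to compound 3 (0.48 log units; beyond the scatter) and a 32-fold lower number from compound 2 to compound 3 (1.51 log units; beyond the scatter), so the substituent on this carbonyl carbon has already swung the read-out across a wide span.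

Compound 4 `CCn1c(C(=O)N(C)CC(=O)O)ccc1C(CC)(CC)c1ccc(OCC(O)C(C)(C)C)c(C)c1` is the next variation at that carbon: (carboxymethyl)(methyl)amino in place of (1-methylprop-2-yn-1-yl)oxy on a carbonyl carbon. Within the data shown here, compound 4 shares with compound 2 the methyl on the amide nitrogen, while the other substituent is a carboxymethyl chain rather than phenyl; no measured step covers that exact exchange. Given that compound 2 gives 6400 nM while compound 1 gives 66 nM, the range of outcomes for an amide here is broad, and the expectation for compound 4 is a higher number than compound 3, by a 4.0-fold higher number from compound 3 to compound 4 (0.60 log units; beyond the scatter). Compound 4 is therefore estimated at 800 nM in this assay, with a range from 120 nM to 6000 nM.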

Compound 4, half-maximal effective concentration: 740 nM
Beside the measured number, compound 4's estimate is 1.1-fold (0.03 log units) above it; the measured number falls inside the stated range.
By their numbers in this assay, from the lowest: compound 1; then compound 3; then compound 4; then compound 2.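

Among amides with a methyl on the nitrogen, carboxymethyl in place of phenyl on that amide-type nitrogen gives an 8.6-fold lower number from compound 2 to compound 4 (0.94 log units; beyond the scatter) in this assay, so the second nitrogen substituent alone moves the read-out, a comparison the earlier compounds did not offer. Among these compounds, compound 4 also fills part of the wide gap left by the earlier compounds, with a 3.7-fold higher number from compound 3 to compound 4 (0.57 log units; beyond the scatter) and an 11-fold higher number from compound 1 to compound 4 (1.05 log units; beyond the scatter) placing this amide above both the ester and the (3-(diethylamino)propyl)amino amide, yet below the phenyl amide. Nothing available here accounts for these differences.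

The compounds shown leave open whether the carboxylic acid or the carbon chain of the carboxymethyl group matters, which a plain ethyl group on that nitrogen would help to separate. They also leave open whether a longer chain ending in a carboxylic acid would fall nearer compound 1 or compound 4.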